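Swapping a difluorophenyl cap for a pentyl chain

The source may report more compounds than this note shows. Statements on the series, on what has been measured and on what is new or still open speak of the compounds shown alone.

Of the compounds shown here, three built on a shared core have been tested in a functional assay on SW-620 cells (Homo sapiens) for antiproliferative activity, read by MTT assay, with a stated time of 72 h; on this read-out lower numbers stand for stronger inhibition and higher numbers for weaker inhibition. Compound 1 `CCCCCc1ccc(C#Cc2cn(CCC(COC(C)=O)COC(C)=O)c(=O)n(C(=O)c3ccccc3)c2=O)cc1` gives only a limit of the assay, > 100000 nM. Compound 2 `CC(=O)OCC(CCn1cc(C#CCCCCl)c(=O)n(C(=O)c2ccccc2)c1=O)COC(C)=O` likewise reaches only the limit > 100000 nM. Compound 3 `O=c1[nH]c(=O)n(CCC(CO)CO)cc1C#Cc1cc(F)cc(F)c1` also stands at the limit, with > 100000 nM. Within the data shown here, because of the limit of > 100000 nM in this assay, at which 3 of the 3 values shown sit, none of the three yields a readable number, and the single step between measured compounds, a step that the two limits leave unreadable from compound 1 to compound 2, cannot be sized. Compound 4 `CCCCCC#Cc1cn(CCC(CO)CO)c(=O)[nH]c1=O` has not yet been measured. It differs from compound 3 in one place: pentyl in place of 3,5-difluorophenyl on a triple-bonded carbon. Among the measured compounds shown here, no measured step mirrors this change, so there is no footing for a direction; the only evidence is that every compound tested so far sits at the limit. The expectation for compound 4 in this assay is therefore a value of 100000 nM, with a range from 30000 nM to 300000 nM. The step expected from compound 3 to compound 4 is estimated as a number no higher from compound 3 to compound 4 (the limit leaves the size open), meaning no change beyond the scatter is anticipated.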

Compound 4, half-maximal inhibitory concentration: > 100000 nM
Compound 4: no number, only a limit; the forecaster's own chance of this, stated with the estimate: 80%; the middle value lies on the limit itself.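

No new step can be read, since compound 3 and compound 4 both give only a limit, and the size of putting pentyl in place of 3,5-difluorophenyl stays unknown: the limit of > 100000 nM in this assay, at which 4 of the 4 values shown sit.

The compounds shown leave open which change to the shared core, if any, would give a readable number in this assay.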